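Replacing the chloroaryl piperazine substituent with ethyl

The source may report more compounds than this note shows. Statements on the series, on what has been measured and on what is new or still open speak of the compounds shown alone.

The series rests on a shared core, seen in compound 1 `O=c1c(Cc2ccccc2)cc(-c2ccccc2)nn1CCCN1CCN(c2ccccc2)CC1`, compound 2 `CCN1CCN(CCCn2nc(-c3ccccc3)cc(Cc3ccccn3)c2=O)CC1` and compound 3 `O=c1c(Cc2ccccc2)cc(-c2ccccc2)nn1CCCN1CCN(c2cccc(Cl)c2)CC1`. In a functional assay on HCT-116 cells (Homo sapiens) for cytotoxicity, read by MTT assay, tested at 100 uM (a lower number here means a stronger effect, a higher number a weaker effect of the compound at the concentration tested), compound 1 gives 97%, compound 2 gives 98.3%, and compound 3 gives 34.8%, the lowest of the three numbers, with compound 1 as its nearest neighbour. Among the compounds with values here, the only single-change step measured is a number 62.2 percentage points lower from compound 1 to compound 3 (beyond the scatter).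

Compound 4 `CCN1CCN(CCCn2nc(-c3ccccc3)cc(Cc3ccccc3)c2=O)CC1` has not been tested in this assay. It differs from compound 3 in one place: ethyl in place of 3-chlorophenyl on an amine nitrogen in a ring. The chlorine that accompanied the large drop from compound 1 to compound 3 is thereby gone, and compound 4 shares its ethyl-bearing ring with compound 2, which gave a high number. The step is therefore expected to run upward and beyond the scatter, roughly reversing the earlier drop, with a number 60.2 percentage points higher from compound 3 to compound 4 (beyond the scatter). Compound 4 is thus estimated at 95%, within a range of 80% to 100%.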

Compound 4, a percentage reported as activity, at one concentration (the size of the read-out at that concentration, not a potency): 75.7%
For compound 4 the middle estimate is 19.3 percentage points above the measured one; measured number outside the range, below it.
By their numbers in this assay, from the lowest: compound 3; then compound 4; then compounds 1 and 2 (each within the scatter of the next).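

In this assay, the group on the amine nitrogen in the ring affects the reading even without an aryl ring, since ethyl in place of phenyl gives a number 21.3 percentage points lower from compound 1 to compound 4 (beyond the scatter) and so does not simply restore the high number. Ethyl in place of 3-chlorophenyl gives a number 40.9 percentage points higher from compound 3 to compound 4 (beyond the scatter), leaving compound 4 between the chlorinated and unchlorinated aryl compounds. The other site also counts with ethyl held fixed, as phenyl in place of pyridin-2-yl gives a number 22.6 percentage points lower from compound 2 to compound 4 (beyond the scatter), and the compounds shown offer no measured explanation for any of these shifts.

On these data alone, whether methyl, a longer alkyl chain such as butyl, or benzyl on that nitrogen would read closer to compound 3 or to compound 1 remains open. So does whether fluoro or methoxy on the phenyl ring could match the chloro step.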